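Replacing the furanylmethyl arm of compound 2 with a hydroxymethoxybenzyl

A few compounds are considered here, and "the series" means these few. Any claim that something is new, unique, unknown or untested is made for them only; others in the source may bear on it.

Measured compounds and values:
compound 1, `Fc1ccc(Cc2ccc3c(NCCCNCc4ccco4)ccnc3c2)c(Cl)c1`, 9.47
compound 2, `Cc1cc(C)cc(Cc2ccc3c(NCCCNCc4ccco4)ccnc3c2)c1`, 9.47
compound 3, `FC(F)(F)c1ccc(-c2ccc3c(NCCCNCc4ccco4)ccnc3c2)cc1`, 9.47

In a physicochemical assay for acid dissociation, compound 2 stands level with compound 1 and compound 3 at the digits shown. The step of no change at the digits printed from compound 1 to compound 2 (within the scatter) and the step of no change at the digits printed from compound 2 to compound 3 (within the scatter), like the step of no change at the digits printed from compound 1 to compound 3 (within the scatter), all alter the aromatic group at the far end of the shared core, and none of them moves the read-out beyond the scatter.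

Compound 4, `COc1cccc(CNCCCNc2ccnc3cc(Cc4cc(C)cc(C)c4)ccc23)c1O`, differs from compound 2 at the other end of the molecule: 2-hydroxy-3-methoxyphenyl in place of furan-2-yl on a saturated chain carbon bound to an amine nitrogen. Among the compounds with values here, no measured step touches this part of the structure, so the three steps above do not bear on it directly; they only show that the read-out has so far been insensitive to changes elsewhere. With nothing pointing either way, the step of a number 0.03 log units higher from compound 2 to compound 4 (within the scatter) is expected to be small, though with a wider range than the measured steps because of the new position. Compound 4 is therefore estimated at 9.5, between 8.9 and 10.1.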

Compound 4, acid dissociation constant: 9.47
Compound 4: the middle estimate sits 0.03 log units above what was measured; the measured number falls inside the stated range.
By their numbers in this assay, from the lowest: compounds 1, 2, 3 and 4 (each within the scatter of the next).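

In this assay, the change at this place gives no change at the digits printed from compound 2 to compound 4 (within the scatter), which extends the earlier picture from the aromatic group at the far end of the shared core to the arm at the other end of the molecule. Here a five-membered aromatic ring with 1 hetero atom and no hydrogen-bond donor gives way to a six-membered aromatic ring of carbon only with 1 hydrogen-bond donor, and the read-out stays within the scatter. No evidence accounts for this result.

Still open, from the compounds shown here alone, is whether the read-out would stay level with an amine or a carboxylic acid on this arm, or with a ring carrying only the hydroxy or only the methoxy group. Also open, going by these compounds, is what a longer chain in the linking part of the molecule would do.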